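Compound 4 of the Pyrazole Amide Set Awaits Measurement

This account rests on a few compounds, and the source may have more. Where it says the series, first, only, none or still open, it means among the compounds named here.

For the measured compounds named here, compound 2 `Cc1ccc(C(=O)Nc2cc(-c3ccccc3)nn2-c2ccccc2)cc1` gives the lowest number of the three compounds so far measured in an assay on CHO cells with metabotropic glutamate receptor 5 (Homo sapiens) as the target (on this read-out higher numbers stand for an effect only at larger amounts of compound and lower numbers for an effect already at smaller amounts), at 30 nM. Compound 1 `O=C(Nc1ccc(Br)cc1CN1C(=O)c2ccccc2C1=O)c1ccccn1` gives 740 nM in this assay, and compound 3 `O=C(Nc1cc(-c2ccccc2)nn1-c1ccccc1)c1ccccc1Cl` gives 2500 nM. Compound 4 `O=C(Nc1cc(-c2ccccc2)nn1-c1ccccc1)c1ccccc1F` differs from compound 2 by 2-fluorophenyl in place of 4-methylphenyl on a carbonyl carbon. Going by the values given here, only one measured step bears on this change: an 83-fold higher number from compound 2 to compound 3 (1.92 log units; beyond the scatter), where a 2-chlorophenyl entered on the same carbonyl carbon in place of the same 4-methylphenyl. The change here is of the same kind, a halogen-bearing ring replacing the methyl-bearing ring, so a large rise is expected, though its size is uncertain. Compound 4 is therefore expected to show a step of a 33-fold higher number from compound 2 to compound 4 (1.52 log units; beyond the scatter) in this assay. Compound 4 is estimated at 1000 nM, within a range from 200 nM to 5000 nM.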

Compound 4, half-maximal effective concentration: 75 nM
The estimate for compound 4 lay 13-fold (1.12 log units) above the measured number; the measured number lies below the stated range.
By their numbers in this assay, from the lowest: compound 2; then compound 4; then compound 1; then compound 3.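

In this assay, a halogen-bearing ring on this carbonyl carbon does not by itself bring a large rise: 2-fluorophenyl in place of 4-methylphenyl gives only a modest step (a 2.5-fold higher number from compound 2 to compound 4 (0.40 log units; beyond the scatter)). Fluoro in place of chloro on an aromatic carbon gives a large step (a 33-fold lower number from compound 3 to compound 4 (1.52 log units; beyond the scatter)), so among these compounds the size of the rise depends on which halogen the ring carries. The compounds shown leave open how a plain phenyl, a 4-fluorophenyl or a 2-methoxyphenyl would compare here, so the roles of the group and its place remain unseparated. No measurement at hand accounts for these steps.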